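The source may hold more compounds than are shown below. What is called first, only, known or untested is meant among the compounds shown, and "the series" means these compounds.

Measured so far:
Compound 1 `COc1ccc(C/N=c2\c(O)c(O)\c2=N/C(C)(C)C)cc1` — 4800 nM in a functional assay for inhibition, with Rattus norvegicus as the target; a higher number here means a weaker inhibitor, a lower number a stronger inhibitor
Compound 2 `Cc1cc(Br)cc(C)c1C/N=c1\c(O)c(O)\c1=N/C(C)(C)C` — 290 nM in this assay

Compound 1 holds the highest of the two numbers in this assay; compound 2 stands lower, and the gap between them lies beyond the scatter. Compound 3 `CC(C)(C)/N=c1\c(O)c(O)\c1=N/Cc1ccccc1` is not yet measured. It differs from compound 1 in one place: hydrogen in place of methoxy on an aromatic carbon. Among the compounds with values here, no step between measured compounds isolates this change, so the data give no size or direction for it. The expectation is a step of no more than the usual scatter, in either direction. Compound 3 is expected to give about 4000 nM in this assay, within a range from 1500 nM to 12000 nM. The expected step is a 1.2-fold lower number from compound 1 to compound 3 (0.08 log units; within the scatter).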

Compound 3, half-maximal inhibitory concentration: 3400 nM
The estimate for compound 3 lay 1.2-fold (0.07 log units) above the measured number; the range from low to high includes it.
By their numbers in this assay, from the lowest: compound 2; then compounds 3 and 1 (each within the scatter of the next).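

In this assay, hydrogen in place of methoxy on an aromatic carbon, para to a large group, gives a 1.4-fold lower number from compound 1 to compound 3 (0.15 log units; within the scatter), the first size read for this change. Loss of the methoxy group therefore moves the number by no more than the scatter, and at this position the group is not needed to hold the value of compound 1. No measurement on hand explains this result.

As far as these compounds go, whether an amine, a carboxylic acid or a longer chain such as butoxy at this position would move the number stays open.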